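Nitrophenyl for fluorophenyl on the pyrazole-bearing core

The source may report more compounds than this note shows. Statements on the series, on what has been measured and on what is new or still open speak of the compounds shown alone.

Measured so far:
compound 1 `O=[N+]([O-])c1cccc(-c2nn(-c3ccccc3)cc2C(Nc2nc3ccccc3s2)c2c(O)ccc3ccccc23)c1` — 43900 nM
compound 2 `COc1ccc2nc(NC(c3cn(-c4ccccc4)nc3-c3ccc(F)cc3)c3c(O)ccc4ccccc34)sc2c1` — 16900 nM

Both numbers come from a functional assay on MCF7 cells (Homo sapiens) for antiproliferative activity, read by MTT assay, with a stated time of 48 h; a lower number here means a stronger inhibitor, a higher number a weaker inhibitor. Compound 1 `O=[N+]([O-])c1cccc(-c2nn(-c3ccccc3)cc2C(Nc2nc3ccccc3s2)c2c(O)ccc3ccccc23)c1` gives 43900 nM in this assay, and compound 2 `COc1ccc2nc(NC(c3cn(-c4ccccc4)nc3-c3ccc(F)cc3)c3c(O)ccc4ccccc34)sc2c1` gives 16900 nM, so compound 2 holds the lower of the two numbers; the gap to compound 1 lies beyond the scatter. The two compounds differ from each other in more than one place, so nothing can be read from their pair about any single change.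

Compound 3 `COc1ccc2nc(NC(c3cn(-c4ccccc4)nc3-c3cccc([N+](=O)[O-])c3)c3c(O)ccc4ccccc34)sc2c1` has not yet been run in this assay. It keeps the core of compound 2 and carries 3-nitrophenyl in place of 4-fluorophenyl on an aromatic carbon. Among the measured compounds shown here, no measured pair isolates this change. For the measured compounds named here, compound 1, the only measured compound bearing the 3-nitrophenyl, gives the higher number with 43900 nM, but it also lacks the methoxy of compound 2, so the weight of the aromatic substituent alone is unknown. The expected step of a 1.5-fold higher number from compound 2 to compound 3 (0.17 log units; within the scatter) is therefore a modest move toward a higher number, possibly not beyond the scatter. Compound 3 is estimated at 25000 nM, with a range from 10000 nM to 60000 nM.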

Compound 3, half-maximal inhibitory concentration: 26800 nM
Estimate against measurement, compound 3: 1.1-fold (0.03 log units) below; the range from low to high includes it.
By their numbers in this assay, from the lowest: compounds 2, 3 and 1 (each within the scatter of the next, the first and the last beyond it).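

In this assay, 3-nitrophenyl in place of 4-fluorophenyl on the aromatic carbon of the five-membered ring gives a 1.6-fold higher number from compound 2 to compound 3 (0.20 log units; within the scatter), so this position does not separate these two aryl groups, although the entering group carries 2 hydrogen-bond acceptors and the leaving group carries 0. Methoxy in place of hydrogen on the shared core, read with 3-nitrophenyl held fixed, gives a 1.6-fold lower number from compound 1 to compound 3 (0.21 log units; within the scatter) and is likewise unresolved. Compound 1 and compound 2 stand apart beyond the scatter, yet neither single change accounts for that gap on its own, so the gap can only be read as the sum of two small steps. Nothing measured here speaks to the reason for these numbers.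

Whether the two changes truly add up remains open, as the compounds shown include no partner that pairs 4-fluorophenyl with hydrogen in place of methoxy. Going by these compounds, it is also open whether this position stays as unresponsive with an amine or a carboxylic acid on the phenyl ring, or whether a longer chain in place of methoxy would produce a step beyond the scatter.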